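Removing the Methoxy Group from an Aryl Amine

This account rests on a few compounds, and the source may have more. Where it says the series, first, only, none or still open, it means among the compounds named here.

Compound 1 `COc1ccc(Nc2n[n+]([O-])c3ccccc3[n+]2[O-])cc1`: 600 nM
Compound 2 `CCNc1n[n+]([O-])c2ccccc2[n+]1[O-]`: 3300 nM
Compound 3 `[O-][n+]1nc(NCCO)[n+]([O-])c2ccccc21`: 2600 nM

Of the compounds shown here, three sharing one core have been measured in a functional assay on MOLT-4 cells (Homo sapiens) for cytotoxicity, read by MTT assay, with a stated time of 48 h; a higher number here means a weaker inhibitor, a lower number a stronger inhibitor. Compound 1 gives 600 nM, the lowest number of the three; compound 3 and compound 2 both stand beyond the scatter above it. Compound 4 `[O-][n+]1nc(Nc2ccccc2)[n+]([O-])c2ccccc21` has not yet been measured. It differs from compound 1 in one place: hydrogen in place of methoxy on an aromatic carbon.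

Going by the values given here, only one measured step is available for comparison, a 1.3-fold lower number from compound 2 to compound 3 (0.10 log units; within the scatter), and it concerns a saturated chain rather than an aromatic ring, so it does not bear directly on this change. It shows only that a small alteration of the group on the amine nitrogen left the number within the scatter. Nothing in the data points to a large shift in either direction. Compound 4 is therefore expected to give about 900 nM, within a range of 400 nM to 2200 nM. That estimate means a step of a 1.5-fold higher number from compound 1 to compound 4 (0.18 log units; within the scatter), expected to fall within or only just beyond the scatter.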

Compound 4, half-maximal inhibitory concentration: 1400 nM
The estimate for compound 4 lay 1.6-fold (0.19 log units) below the measured number, within the range that was stated.
By their numbers in this assay, from the lowest: compound 1; then compounds 4, 3 and 2 (each within the scatter of the next, the first and the last beyond it).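

Removing the methoxy has a measurable effect in this assay, with a 2.3-fold higher number from compound 1 to compound 4 (0.37 log units; beyond the scatter) showing that this aromatic carbon, para to a large group, matters more than the chain carbon changed earlier. The phenyl ring without methoxy separates from only one of the two chains on the nitrogen, giving a 2.4-fold lower number from compound 2 to compound 4 (0.37 log units; beyond the scatter) when it replaces ethyl, but a 1.9-fold lower number from compound 3 to compound 4 (0.27 log units; within the scatter) when it replaces 2-hydroxyethyl. Nothing measured here gives a reason for these shifts.

Going by these compounds, whether ethoxy, hydroxy or a chlorine atom on this same carbon would give a number closer to that of methoxy or to that of hydrogen remains open. So does whether an amine or a carboxylic acid there would move the number in the opposite direction.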